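A few compounds are considered here, and "the series" means these few. Any claim that something is new, unique, unknown or untested is made for them only; others in the source may bear on it.

Measured compounds:
compound 1 `O=C(Nc1ccc2sc(-c3ccccc3F)nc2c1)N1CCCCC1` — > 50 uM
compound 2 `O=C(Nc1ccc2sc(-c3cccc(F)c3F)nc2c1)N1CCCC1` — > 50 uM

In an ADME assay on HepG2 cells (Homo sapiens) for inhibition, read by resazurin assay, with a stated time of 48 h (on this read-out higher numbers stand for an effect only at larger amounts of compound and lower numbers for an effect already at smaller amounts), compound 1 reaches only a limit of the assay, > 50 uM. Compound 2 likewise returns only a limit in this assay, > 50 uM. For the measured compounds named here, compound 2 thus stands at the limit of > 50 uM in this assay, at which 2 of the 2 values shown sit, together with the one other value shown, so no number separates the two measured compounds and no step between them can be sized.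

Compound 3 `O=C(Nc1ccc2sc(-c3cccc(F)c3)nc2c1)N1CCCC1` has not yet been measured. It differs from compound 2 by hydrogen in place of fluoro on an aromatic carbon, which the wider view describes as a change from 2,3-difluorophenyl to 3-fluorophenyl; the other fluoro group and the rest of the shared core stay in place.

With both measured values sitting at the same limit, there is no basis for expecting a step in this assay beyond the usual scatter in either direction. Compound 3 is therefore estimated at about 80 uM, with a range from 50 uM to 200 uM. That amounts to an expected step that the limit leaves unreadable from compound 2 to compound 3 in this assay, most likely reported again as a limit rather than a number.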

Compound 3, concentration for 90% of the maximal effect: > 50 uM
Compound 3: only a limit was reported (the forecaster's own chance of this, stated with the estimate: 85%); the middle value is on the limit's open side.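

Compound 3 returns only a limit in this assay, > 50 uM. The step from compound 2 to this compound cannot be read, because the values shown share one limit: the limit of > 50 uM in this assay, at which 3 of the 3 values shown sit.

The compounds shown leave open whether hydrogen in place of fluoro on the aromatic carbon makes any difference in this assay; none of them gives a number.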